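The compounds below may be only part of what the source reports. "The series", "measured", "known", "first", "only" and "open" are said of these compounds alone.

Measured so far in an assay for inhibition of apolipoprotein B-100 (Homo sapiens), tested at 100 nM; on this read-out higher numbers stand for weaker inhibition and lower numbers for stronger inhibition:

- compound 1, `Cc1cccc(C(=O)Nc2ccc3c(c2)CC(NS(=O)(=O)c2ccccc2)C3)c1-c1ccc(F)cc1`, gives 1.2 nM 
- compound 2, `COC(=O)NCC1Cc2ccc(NC(=O)c3cccc(C)c3-c3ccc(C(F)(F)F)cc3)cc2C1`, gives 4.1 nM 

Two compounds of the series carry a number in this assay. Compound 2 has the higher of the two numbers; compound 1 sits lower, and the gap between the two is beyond the usual scatter. Among the measured compounds shown here, no pair among the measured compounds differs in only one place, so no single-change step is available as a yardstick for what follows.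

The next compound, compound 3, `COC(=O)NCC1Cc2ccc(NC(=O)c3cc(C)cc(C)c3-c3ccc(C(F)(F)F)cc3)cc2C1`, differs from compound 2 by one change: methyl in place of hydrogen on an aromatic carbon. Nothing in the measured pair speaks directly to this change. In the absence of any comparable step, the working expectation for the move from compound 2 to compound 3 is a 1.0-fold lower number from compound 2 to compound 3 (0.01 log units; within the scatter), a step that is expected to stay within the usual scatter, in either direction. Compound 3 is therefore estimated at 4 nM, with a range of 1.5 nM to 11 nM, close to compound 2.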

Compound 3, half-maximal inhibitory concentration: 2.2 nM
For compound 3 the middle estimate is 1.8-fold (0.26 log units) above the measured one; the range from low to high includes it.
By their numbers in this assay, from the lowest: compounds 1, 3 and 2 (each within the scatter of the next, the first and the last beyond it).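

Among the compounds shown here, the first single-place step, read in this assay, is a 1.9-fold lower number from compound 2 to compound 3 (0.27 log units; within the scatter) for methyl in place of hydrogen on an aromatic carbon. For the compounds shown here, this position, para to a 4-(trifluoromethyl)phenyl group and meta to a methyl group, therefore accepts one added methyl with no step beyond the scatter, which is the first direct reading at this position on the shared core of compound 2. No measurement at hand bears on why the step has this size.

A single methyl says nothing about how other groups behave at this position, so a methoxy group, a chlorine atom, an amine, a carboxylic acid or a longer chain could each give a step of quite another size on compound 2. Going by these compounds, it also remains open whether the same methyl would give a comparable step on compound 1, whose core differs from that of compound 2 in more than one place.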